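Tolerated Concentration Limits from Compound 3 to Compound 4

The source may report more compounds than this note shows. Statements on the series, on what has been measured and on what is new or still open speak of the compounds shown alone.

Measured in an ADME assay on MT4 cells (Homo sapiens) for cytotoxicity, read by MTT assay, with a stated time of 4 days; a higher number here means that more compound is tolerated, a lower number that less compound is tolerated:
Compound 1, `CN(C)c1nc(Cc2c(F)cccc2F)cc(=O)[nH]1`, gives > 94000 nM, a limit of the assay.
Compound 2, `O=c1cc(Cc2c(F)cccc2F)nc(N2CCCCC2)[nH]1`, gives > 82000 nM, a limit of the assay.
Compound 3, `Cc1c(Cc2c(F)cccc2F)nc(N(C)C)[nH]c1=O`, gives > 89000 nM, a limit of the assay.

Within the data shown here, compound 3 therefore stands at a limit in this assay, and the two other values shown are limits as well, so no compound among the three has a numbered half-maximal cytotoxic concentration. The two measured steps, a step that the two limits leave unreadable from compound 1 to compound 2 and a step that the two limits leave unreadable from compound 1 to compound 3, are both unreadable for the same reason: each is bounded by limits on both sides, as recorded in the limit of > 82000 nM in this assay, at which 1 of the 3 values shown sits, the limit of > 89000 nM in this assay, at which 1 of the 3 values shown sits, and (the limit of > 94000 nM in this assay, at which 1 of the 3 values shown sits).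

Compound 4, `Cc1c(Cc2c(F)cccc2F)nc(N2CCC(C)CC2)[nH]c1=O`, differs from compound 3 by 4-methylpiperidin-1-yl in place of dimethylamino on an aromatic carbon. Among the measured compounds shown here, no measured step bears readably on this change, so no size or direction of step can be drawn from the data. The expectation for compound 4 is that it also reaches the limit of this assay, an estimated 90000 nM with a range of 40000 nM to 150000 nM. The estimated step that the limit leaves unreadable from compound 3 to compound 4 is expected to lie within the scatter.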

Compound 4, half-maximal cytotoxic concentration: > 75000 nM
Compound 4: only a limit was reported; the forecaster's own chance of this, stated with the estimate: 85%; the middle value does not contradict the limit.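

In this assay compound 4 gives > 75000 nM, a limit of the assay. Compound 3 also stands at a limit, so the step between compound 3 and compound 4 cannot be read. The compounds shown leave open at what concentration any of them becomes cytotoxic.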